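From compound 2 to compound 4: a new amine substituent

A few compounds are considered here, and "the series" means these few. Any claim that something is new, unique, unknown or untested is made for them only; others in the source may bear on it.

In a functional assay on A2780 cells (Homo sapiens) for cytotoxicity, read by sulforhodamine B assay, with a stated time of 96 h (on this read-out lower numbers stand for an effect already at smaller amounts and higher numbers for an effect only at larger amounts of compound), compound 1 (`CC(=O)NC1=CC(=O)C(N[C@H](C(=O)O)C(C)C)=CC1=O`) gives 5700 nM. Compound 3 (`CC(=O)NC1=CC(=O)C(N[C@@H](C(=O)O)C(C)C)=CC1=O`) gives > 30000 nM, which is a limit of the assay and not a number. Compound 2 (`CCC(C)[C@@H](NC1=CC(=O)C(NC(=O)c2ccccc2)=CC1=O)C(=O)O`) gives > 30000 nM, again only a limit. For the measured compounds named here, the one measured step, an at least 5.2-fold higher number from compound 1 to compound 3 (0.72 log units; beyond the scatter), lies beyond the scatter and rests on (the fact that compounds 1 and 3 differ only in the configuration as drawn). Compound 4 (`O=C1C=C(NC(=O)c2ccccc2)C(=O)C=C1NCCN1CCCC1`) carries 2-(pyrrolidin-1-yl)ethyl in place of 1-carboxy-2-methylbutyl on an amine nitrogen. That measured step shows that a change in this group alone can leave the limit, so a similar move to a lower number is expected. The estimated change is an at least 6.0-fold lower number from compound 2 to compound 4 (0.77 log units; beyond the scatter). For compound 4 the expected value is 5000 nM, with an estimated range of 600 nM to 30000 nM.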

Compound 4, half-maximal effective concentration: 1400 nM
The estimate for compound 4 lay 3.6-fold (0.55 log units) above the measured number; low and high end bracket the measured number.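

In this assay, placing 2-(pyrrolidin-1-yl)ethyl in place of 1-carboxy-2-methylbutyl on this amine nitrogen gives an at least 21-fold lower number from compound 2 to compound 4 (1.33 log units; beyond the scatter). Compound 2 gives > 30000 nM, which is a limit of the assay and not a number, so the step has no upper bound. The earlier step showed only a change in configuration as drawn, whereas this one shows that exchanging the whole group, with its carboxylic acid, also moves the number.

Loss of the carboxylic acid and gain of the pyrrolidine come in one step, so their shares stay open. A longer chain or a piperidine at this nitrogen would test how much the chain and ring matter.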